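Shortening the Ether Chain on a Hydroxychalcone Core

This account rests on a few compounds, and the source may have more. Where it says the series, first, only, none or still open, it means among the compounds named here.

The measured compounds and their values in a functional assay on MDA-MB-231 cells (Homo sapiens) for antiproliferative activity, read by sulforhodamine B assay; a lower number here means a stronger inhibitor of growth, a higher number a weaker inhibitor of growth:
Compound 1, `O=C(/C=C/c1ccc(O)cc1)c1c(O)cccc1OCC1CCCCC1`, gives only a limit, > 30000 nM.
Compound 2, `O=C(/C=C/c1ccc(O)cc1)c1c(O)cccc1OCCC1CCCC1`, gives 3340 nM.
Compound 3, `CC(C)(C)CCOc1cccc(O)c1C(=O)CCc1ccc(O)cc1`, gives only a limit, > 30000 nM.

Going by the values given here, compound 2 is therefore the only compound with an actual number; the other two sit at a limit of the assay. Among the compounds with values here, the single measured step, an at least 8.9-fold lower number from compound 1 to compound 2 (0.95 log units; beyond the scatter), shows that the shape of the group on the saturated chain carbon bound to the ring oxygen matters a great deal, with the limit of > 30000 nM in this assay, at which 2 of the 3 values shown sit, marking where compound 1 stands.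

Compound 4, `CC(C)COc1cccc(O)c1C(=O)/C=C/c1ccc(O)cc1`, differs from compound 2 in one place: isopropyl in place of cyclopentylmethyl on a saturated chain carbon bound to an oxygen on an aromatic ring. The ring is lost and a much smaller branch remains. The measured step runs in a different direction, so it gives no direct guide, only the warning that changes here can be large. The number for compound 4 is expected to rise, with a 3.0-fold higher number from compound 2 to compound 4 (0.48 log units; beyond the scatter) as the estimated step. Compound 4 is thus estimated at 10000 nM, within 2500 nM to 30000 nM.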

Compound 4, concentration for 50% growth inhibition: 3520 nM
Compound 4: middle estimate off by 2.8-fold (0.45 log units), on the high side; the measured number falls inside the stated range.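

In this assay, the step from cyclopentylmethyl to isopropyl is a 1.1-fold higher number from compound 2 to compound 4 (0.02 log units; within the scatter), so the two groups cannot be told apart here, and the cyclopentylmethyl ring is not needed for the growth inhibition seen in compound 2. The other new step, an at least 8.5-fold lower number from compound 1 to compound 4 (0.93 log units; beyond the scatter), shows that a group with no ring also stands well apart from cyclohexyl, so having fewer heavy atoms does not by itself separate the active compounds from the inactive one. Compound 1 gives a limit rather than a number, so that step is only a minimum: the limit of > 30000 nM in this assay, at which 2 of the 4 values shown sit.

The compounds shown leave open whether a longer chain at this oxygen would keep the activity of compound 4. They also leave open how an amine or a carboxylic acid at the end of the chain would fare.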